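From Chloro to tert-Butyl in a Growth-Inhibition Series

A few compounds are considered here, and "the series" means these few. Any claim that something is new, unique, unknown or untested is made for them only; others in the source may bear on it.

Compound 1 `Cc1ccc(CN2CC=C(CCC(=O)NO)C2=O)cc1` and compound 2 `O=C(CCC1=CCN(Cc2ccc(Cl)cc2)C1=O)NO` share one core and differ only by chloro in place of methyl on an aromatic carbon. In a functional assay on PC-3 cells (Homo sapiens) for inhibition, read by sulforhodamine B assay (on this read-out higher numbers stand for weaker inhibition of growth and lower numbers for stronger inhibition of growth), compound 1 gives 4620 nM, and compound 2 gives 4620 nM; the step of no change at the digits printed from compound 1 to compound 2 (within the scatter) leaves the two level. Compound 3 `CC(C)(C)c1ccc(CN2CC=C(CCC(=O)NO)C2=O)cc1` differs from compound 2 by tert-butyl in place of chloro on an aromatic carbon. Within the data shown here, only that one measured step bears on this change, and it showed nothing beyond the scatter in this assay, so no step beyond the scatter is expected here either. Compound 3 is therefore estimated at 4000 nM, between 1500 nM and 12000 nM, an expected step of a 1.2-fold lower number from compound 2 to compound 3 (0.06 log units; within the scatter).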

Compound 3, concentration for 50% growth inhibition: 1830 nM
Estimate against measurement, compound 3: 2.2-fold (0.34 log units) above; the measured number falls inside the stated range.
By their numbers in this assay, from the lowest: compound 3; then compounds 1 and 2 (each within the scatter of the next).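

In this assay, this aromatic carbon proves sensitive to its substituent: tert-butyl in place of chloro gives a 2.5-fold lower number from compound 2 to compound 3 (0.40 log units; beyond the scatter), and tert-butyl in place of methyl gives a 2.5-fold lower number from compound 1 to compound 3 (0.40 log units; beyond the scatter). Methyl and chloro had stood level, so tert-butyl brings the first change beyond the scatter at this position. Nothing available here accounts for this step. The compounds shown leave open whether an amine, a carboxylic acid or a longer alkyl chain on this carbon would lower the number further, or raise it.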